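Urea series: phenylcyclopentyl variations against acyl-CoA:cholesterol acyltransferase

This account rests on a few compounds, and the source may have more. Where it says the series, first, only, none or still open, it means among the compounds named here.

Measured compounds:
compound 1 `Cc1ccc(C2(CNC(=O)Nc3c(C(C)C)cccc3C(C)C)CCCC2)cc1` 25 nM
compound 2 `CC(C)c1cccc(C(C)C)c1NC(=O)NCC1(c2ccc([N+](=O)[O-])cc2)CCCC1` 131 nM
compound 3 `CC(C)c1cccc(C(C)C)c1NC(=O)NCC1(c2cccc(N)c2)CCCC1` 21 nM

In an assay on microsomes for inhibition of acyl-CoA:cholesterol acyltransferase (Oryctolagus cuniculus) (a lower number here means a stronger inhibitor, a higher number a weaker inhibitor), compound 3 gives the lowest of the three numbers, but the step of a 1.2-fold lower number from compound 1 to compound 3 (0.08 log units; within the scatter) is within the scatter; only compound 2 stands clearly apart, as a 6.2-fold lower number from compound 2 to compound 3 (0.80 log units; beyond the scatter) shows. Compound 4 `COC(=O)c1ccc(C2(CNC(=O)Nc3c(C(C)C)cccc3C(C)C)CCCC2)cc1` is not yet measured. It differs from compound 3 by 4-(methoxycarbonyl)phenyl in place of 3-aminophenyl on a saturated ring carbon.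

Among the compounds with values here, two measured steps bear on this change. The step of a 5.2-fold higher number from compound 1 to compound 2 (0.72 log units; beyond the scatter) puts a nitro group on the aromatic ring in place of methyl and raises the number modestly. The step of a 6.2-fold lower number from compound 2 to compound 3 (0.80 log units; beyond the scatter) removes the 4-nitrophenyl group in favour of 3-aminophenyl and brings the number back down. The entering 4-(methoxycarbonyl)phenyl group, like 4-nitrophenyl, carries no hydrogen-bond donor and two acceptors, so a modest rise from compound 3 in this assay is expected, of the order of the step from compound 1 to compound 2, though this rests on one pair only. Compound 4 is therefore estimated at 70 nM, with a range from 25 nM to 200 nM, an expected step of a 3.3-fold higher number from compound 3 to compound 4 (0.52 log units; beyond the scatter).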

Compound 4, half-maximal inhibitory concentration: 360 nM
For compound 4 the middle estimate is 5.1-fold (0.71 log units) below the measured one; the whole stated range lies below it.
By their numbers in this assay, from the lowest: compounds 3 and 1 (each within the scatter of the next); then compound 2; then compound 4.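

In this assay the group on the saturated ring carbon can cost far more than the nitro compound suggested: the change reads as a 17-fold higher number from compound 3 to compound 4 (1.23 log units; beyond the scatter) and, against the methyl analogue, as a 14-fold higher number from compound 1 to compound 4 (1.16 log units; beyond the scatter), which leaves compound 4 the weakest of the four, with its steps to all the others beyond the scatter. Methoxycarbonyl and nitro, both without a hydrogen-bond donor, are also not equivalent on the aromatic carbon, as a 2.7-fold higher number from compound 2 to compound 4 (0.44 log units; beyond the scatter) shows, so the absence of a donor does not by itself set the number in this set. No measurement is at hand that would explain the size of these steps.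

The compounds shown leave open whether the rise belongs to the methoxycarbonyl group itself or to the place of the substituent on the phenyl ring, since 3-aminophenyl and 4-(methoxycarbonyl)phenyl differ in both. Also open, from the compounds shown here alone, is how a carboxylic acid, a primary amide or an ethyl ester would read in place of methoxycarbonyl on the same aromatic carbon, and whether any of them would return to the level of compound 1.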